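The source may report more compounds than this note shows. Statements on the series, on what has been measured and on what is new or still open speak of the compounds shown alone.

Measured compounds:
compound 1, `O=C(Nc1ccc(F)cc1)C1(c2ccc3c(n2)CCN3c2ccccn2)CCC1`, gives 10.9 nM in an assay on HeLa cells for inhibition of Indoleamine 2,3-dioxygenase 1 (Homo sapiens); on this read-out lower numbers stand for stronger inhibition and higher numbers for weaker inhibition;
compound 2, `O=C(Nc1ccc(Cl)cc1)C1(c2ccc3c(n2)CCN3c2ccccn2)CCC1`, gives 2.3 nM in this assay;
compound 3, `O=C(Nc1ccc(F)cc1)C1(c2ccc3c(c2)CCN3c2ccccn2)CCC1`, gives 3.1 nM in this assay.

Among these three, compound 1 has the highest number in this assay, the weakest inhibition of the set. For the measured compounds named here, its nearest neighbour is compound 3, whose value is lower by a margin beyond the scatter; compound 2 lies furthest off, the only measured step being a 4.7-fold lower number from compound 1 to compound 2 (0.68 log units; beyond the scatter).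

Compound 4, `O=C(C1CC1)N1CCc2nc(C3(C(=O)Nc4ccc(F)cc4)CCC3)ccc21`, differs from compound 1 in one place: cyclopropylcarbonyl in place of pyridin-2-yl on a nitrogen on an aromatic ring in a ring. Going by the values given here, no measured step touches this position. Among the compounds with values here, the one step in hand, from compound 1 to compound 2, concerns a halogen on the aromatic carbon of the amide-bearing ring, and compound 3 differs from compound 1 in the ring fusion; neither tells how this assay responds to a change on the nitrogen of the five-membered ring. On these data alone, what remains is that every measured compound carries the pyridin-2-yl group there, so its removal is untested ground. On that basis a modest shift toward a higher number is expected, with wide uncertainty: compound 4 is estimated at 30 nM, between 8 nM and 120 nM, which would be a step of a 2.8-fold higher number from compound 1 to compound 4 (0.44 log units; beyond the scatter).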

Compound 4, half-maximal inhibitory concentration: 8 nM
Compound 4: middle estimate off by 3.8-fold (0.57 log units), on the high side, within the range that was stated.
By their numbers in this assay, from the lowest: compounds 2 and 3 (each within the scatter of the next); then compounds 4 and 1 (each within the scatter of the next).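

In this assay the exchange on this nitrogen gives a 1.4-fold lower number from compound 1 to compound 4 (0.13 log units; within the scatter) and so stays within the scatter, which means that for this pair the assay does not separate cyclopropylcarbonyl from pyridin-2-yl. The earlier compounds shown here all carried pyridin-2-yl at this place and could say nothing about it; compound 4 shows that, on the core of compound 1, a six-membered aromatic ring on this nitrogen is not needed for a value in the range of compound 1, and that a carbonyl with a three-membered non-aromatic ring can stand in its place. No supporting data bear on why the two groups read alike.

The compounds shown leave open whether cyclopropylcarbonyl behaves the same way alongside the chloro of compound 2 or on the core of compound 3. They also leave open how far this nitrogen accepts other groups, such as acetyl, benzoyl, a plain methyl or a longer acyl chain, and so whether the carbonyl or the three-membered ring counts for more.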